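The source may hold more compounds than are shown below. What is called first, only, known or untested is meant among the compounds shown, and "the series" means these compounds.

Among the three compounds measured in a functional assay on DLD-1 cells (Homo sapiens) for cytotoxicity, read by MTT assay, with a stated time of 48 h (a higher number here means a weaker inhibitor, a lower number a stronger inhibitor), compound 3 `COc1ccc(-c2cn(/N=C/c3cc4cc(C)ccc4nc3Cl)c(N)n2)cc1` stands at the high end with 25700 nM. Compound 2 `Cc1ccc(-c2cn(/N=C/c3cc4cc(C)ccc4nc3Cl)c(N)n2)cc1` gives 25200 nM, and a 1.0-fold higher number from compound 2 to compound 3 (0.01 log units; within the scatter). Compound 1 `Cc1ccc2nc(Cl)c(/C=N/n3cc(-c4ccccc4)nc3N)cc2c1` gives 8790 nM; a 2.9-fold higher number from compound 1 to compound 3 (0.47 log units; beyond the scatter) and a 2.9-fold higher number from compound 1 to compound 2 (0.46 log units; beyond the scatter). Compound 4 `Cc1ccc2nc(Cl)c(/C=N/n3cc(-c4ccc(Br)cc4)nc3N)cc2c1` differs from compound 3 by bromo in place of methoxy on an aromatic carbon. The steps from compound 1 to compound 2 and from compound 1 to compound 3 both concern this same position, and each raised the number modestly, while the swap of methyl for methoxy between compound 2 and compound 3 changed nothing beyond the scatter. Going by the values given here, no measured step involves bromo, so the expectation rests on those three. For compound 4 the number is expected near 20000 nM, within 8000 nM to 50000 nM, with a 1.3-fold lower number from compound 3 to compound 4 (0.11 log units; within the scatter) estimated as the step.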

Compound 4, half-maximal inhibitory concentration: 39300 nM
For compound 4 the middle estimate is 2.0-fold (0.29 log units) below the measured one, within the range that was stated.
By their numbers in this assay, from the lowest: compound 1; then compounds 2, 3 and 4 (each within the scatter of the next).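

In this assay bromo at this place cannot be told apart from methoxy (a 1.5-fold higher number from compound 3 to compound 4 (0.18 log units; within the scatter)) or from methyl (a 1.6-fold higher number from compound 2 to compound 4 (0.19 log units; within the scatter)). Only hydrogen, in compound 1, stands apart (a 4.5-fold higher number from compound 1 to compound 4 (0.65 log units; beyond the scatter)), so among these four compounds each of the three groups goes with a higher number than hydrogen. No supporting data explain why this is so.

On these data alone, whether an amine or a carboxylic acid at this place would match these three groups or come closer to compound 1 remains open.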